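From diethyl to trimethyl on the dioxoimidazolidinyl group

A few compounds are considered here, and "the series" means these few. Any claim that something is new, unique, unknown or untested is made for them only; others in the source may bear on it.

Compound 1 `Cc1cc(N(C)C(N)=O)cc(C)c1CCS(=O)(=O)N1CCC2(CC1)N=C(c1ccc(OC(F)(F)F)cc1)NC2=O` gives 48 mL.min-1.g-1
Compound 2 `Cc1cc(N2C(=O)NC(=O)C2C)cc(C)c1CCS(=O)(=O)N1CCC2(CC1)N=C(c1ccc(OC(F)(F)F)cc1)NC2=O` gives 71 mL.min-1.g-1
Compound 3 `CCC1(CC)C(=O)NC(=O)N1c1cc(C)c(CCS(=O)(=O)N2CCC3(CC2)N=C(c2ccc(OC(F)(F)F)cc2)NC3=O)c(C)c1` gives 29 mL.min-1.g-1

In an ADME assay on microsomes from liver (Homo sapiens) for pharmacokinetics, read by LC-MS, using NADPH, with a stated time of 30 min, tested at 1 uM (a lower number here means slower removal, a higher number faster removal of the compound), compound 3 stands at the low end of these three numbers, clearly under compound 2 and within the scatter of compound 1. Compound 4 `Cc1cc(N2C(=O)N(C)C(=O)C2(C)C)cc(C)c1CCS(=O)(=O)N1CCC2(CC1)N=C(c1ccc(OC(F)(F)F)cc1)NC2=O` has not yet been measured. The difference 3,5,5-trimethyl-2,4-dioxoimidazolidin-1-yl in place of 5,5-diethyl-2,4-dioxoimidazolidin-1-yl on an aromatic carbon lies on an aromatic carbon, meta to two methyl groups. Going by the values given here, no measured compound carries the 3,5,5-trimethyl-2,4-dioxoimidazolidin-1-yl group, so no step speaks to it directly. The nearest guide is a 2.4-fold lower number from compound 2 to compound 3 (0.39 log units; beyond the scatter) as a modest change on the same ring. The step of a 1.7-fold lower number from compound 1 to compound 3 (0.22 log units; within the scatter) bears less on it, as it starts from a group without that ring. In this assay a step of a 1.3-fold higher number from compound 3 to compound 4 (0.12 log units; within the scatter) is therefore expected, small and upward, with no change beyond the scatter. For compound 4 the estimate is 38 mL.min-1.g-1 in a range of 18 mL.min-1.g-1 to 75 mL.min-1.g-1 as expected from these steps.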

Compound 4, intrinsic clearance in microsomes: 330 mL.min-1.g-1
Compound 4: middle estimate off by 8.7-fold (0.94 log units), on the low side, outside the stated range (above it).
By their numbers in this assay, from the lowest: compounds 3, 1 and 2 (each within the scatter of the next, the first and the last beyond it); then compound 4.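

In this assay, going by these compounds alone, the 3,5,5-trimethyl-2,4-dioxoimidazolidin-1-yl group in place of the 5,5-diethyl-2,4-dioxoimidazolidin-1-yl group gives an 11-fold higher number from compound 3 to compound 4 (1.06 log units; beyond the scatter) on this aromatic carbon, para to a large group, so the position proves far more sensitive than the earlier compounds showed. The rise also holds against the other two compounds, with a 4.6-fold higher number from compound 2 to compound 4 (0.67 log units; beyond the scatter) and a 6.9-fold higher number from compound 1 to compound 4 (0.84 log units; beyond the scatter), and the shared dioxoimidazolidinyl ring therefore does not by itself keep the number low, since compound 2, compound 3 and compound 4 all carry it. Nothing given here accounts for this rise. The change replaces the two ethyl groups with methyl groups and also removes the hydrogen-bond donor, and the compounds shown do not separate these two differences. Going by these compounds, how a propyl chain or an amine on this ring would read also remains open.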